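This account rests on a few compounds, and the source may have more. Where it says the series, first, only, none or still open, it means among the compounds named here.

Three compounds built on one shared core are considered here. Compound 1 `COc1ccc(/C=N/NC(=O)Nc2ccc(Oc3ccnc4cc(OCCCN5CCC(C)CC5)c(OC)cc34)c(F)c2)cc1` was tested in an ADME assay on PBL cells (Homo sapiens) for cytotoxicity, read by MTT assay, with a stated time of 72 h (a lower number here means a stronger inhibitor, a higher number a weaker inhibitor), where compound 1 gives 23000 nM, a weak effect on the cells. Compound 2 `COc1cc2c(Oc3ccc(NC(=O)N/N=C/c4ccc([N+](=O)[O-])cc4)cc3F)ccnc2cc1OCCCN1CCC(C)CC1` was also taken into this assay, but for compound 2 the result is "not determined" (no result reported), so no number shows where it stands; the only measured point on this core is compound 1. Compound 3 `COc1cc2c(Oc3ccc(NC(=O)N/N=C/c4ccc(F)cc4Cl)cc3F)ccnc2cc1OCCCN1CCC(C)CC1` has not been measured. It differs from compound 2 in one place: 2-chloro-4-fluorophenyl in place of 4-nitrophenyl on a carbon with a double bond to nitrogen. Within the data shown here, with no measured step on this core to guide the size of such a change, the expectation is that this assay will show a weak effect for compound 3 much as it did for compound 1, with no change beyond the usual scatter in either direction. On that basis compound 3 is expected to give about 20000 nM in this assay, within a range from 7000 nM to 60000 nM.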

Compound 3, half-maximal inhibitory concentration: 79500 nM
The estimate for compound 3 lay 4.0-fold (0.60 log units) below the measured number, and the stated range ends below it.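

In this assay the group on a carbon with a double bond to nitrogen makes a measurable difference: 2-chloro-4-fluorophenyl in place of 4-methoxyphenyl gives a 3.5-fold higher number from compound 1 to compound 3 (0.54 log units; beyond the scatter) and so a weaker effect on the cells. Among these compounds, this is the first step on the shared core that can be read, and it shows that this position can shift the result beyond the usual scatter, though only modestly. No information is available on why the number rises with this change.

Going by these compounds, the step from compound 2 to compound 3 cannot be read, so the place of 4-nitrophenyl remains unknown. Also open, on these data alone, is how much of the step belongs to the chlorine and how much to the fluorine, and whether a ring carrying an amine or a carboxylic acid would move the number further in either direction.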